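Sulfonamide diamines: aryl swap on the benzylic amine

The source may report more compounds than this note shows. Statements on the series, on what has been measured and on what is new or still open speak of the compounds shown alone.

Measured so far:
- compound 1 `O=S(=O)(NCCCNCc1ccc(Cl)c(Cl)c1)c1cc(C(F)(F)F)cc(C(F)(F)F)c1`: 1500 nM
- compound 2 `O=S(=O)(NCCCNCc1cccc2ccccc12)c1cc(C(F)(F)F)cc(C(F)(F)F)c1`: 3100 nM

In a functional assay on A2780 cells (Homo sapiens) for inhibition, read by MTT assay, with a stated time of 72 h (on this read-out higher numbers stand for weaker inhibition of growth and lower numbers for stronger inhibition of growth), compound 2 gives 3100 nM, the highest of the two numbers; the nearest is compound 1 with 1500 nM. Going by the values given here, the one step measured, a 2.1-fold higher number from compound 1 to compound 2 (0.32 log units; beyond the scatter), is modest and beyond the scatter.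

Compound 3 `O=S(=O)(NCCCNCc1cccc(Cl)c1)c1cc(C(F)(F)F)cc(C(F)(F)F)c1` is not yet measured. It differs from compound 2 by 3-chlorophenyl in place of naphthalen-1-yl on a saturated chain carbon bound to an amine nitrogen. Among the compounds with values here, the measured step from compound 1 to compound 2 bears on this change only loosely: it shows that a chlorinated phenyl gives a lower number than the naphthalen-1-yl group, but compound 3 carries one chlorine where compound 1 carries two, and no step with a single chlorine is available. The expected step of a 1.2-fold lower number from compound 2 to compound 3 (0.08 log units; within the scatter) is therefore small, if any, with a slight lean toward a lower number. For compound 3 the estimate in this assay is 2600 nM, within a range of 1100 nM to 7000 nM.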

Compound 3, concentration for 50% growth inhibition: 2200 nM
For compound 3 the middle estimate is 1.2-fold (0.07 log units) above the measured one; low and high end bracket the measured number.
By their numbers in this assay, from the lowest: compounds 1, 3 and 2 (each within the scatter of the next, the first and the last beyond it).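

In this assay, the single-ring 3-chlorophenyl group and the fused naphthalen-1-yl group on a saturated chain carbon bound to an amine nitrogen are not resolved, with a 1.4-fold lower number from compound 2 to compound 3 (0.15 log units; within the scatter) as the step. Hydrogen in place of chloro on an aromatic carbon, with a 1.5-fold higher number from compound 1 to compound 3 (0.17 log units; within the scatter) as the step, is not resolved either, so compound 3 stands apart from neither neighbour and only compound 1 and compound 2 remain separated beyond the scatter. No supporting data are available to explain these results.

Going by these compounds, whether a methoxy group or a carboxylic acid in place of chloro on the aromatic ring would give a clearly different number stays open. The compounds shown also leave open what a longer chain in the shared core would do.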